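From isopropoxycarbonyl to 1-benzofuran-2-yl on the shared core

A few compounds are considered here, and "the series" means these few. Any claim that something is new, unique, unknown or untested is made for them only; others in the source may bear on it.

In a toxicity assay on NIH3T3 cells (Mus musculus) for cytotoxicity, read by resazurin assay (on this read-out lower numbers stand for an effect already at smaller amounts and higher numbers for an effect only at larger amounts of compound), compound 2 (`CC(C)OC(=O)c1ccc(NCc2cncn2Cc2ccc(-c3ccccc3)cc2)cc1-c1ccccc1`) gives > 10000 nM, which is a limit and not a number. Compound 1 (`c1ccc(-c2ccc(Cn3cncc3CNc3ccc(-c4nc5ccccc5s4)c(-c4ccccc4)c3)cc2)cc1`) gives > 1000 nM, also a limit. Compound 3 (`c1ccc(-c2ccc(Cn3cncc3CNc3ccc(-c4cc5ccccc5o4)c(-c4ccccc4)c3)cc2)cc1`) follows from compound 2 by 1-benzofuran-2-yl in place of isopropoxycarbonyl on an aromatic carbon. Among the measured compounds shown here, the one measured step bearing on this carbon is a step that the two limits leave unreadable from compound 1 to compound 2, so its size offers no firm guide. Compound 3 has a fused aromatic group there, as compound 1 does, so a modest shift towards lower numbers in this assay is expected. The expected change is an at least 2.0-fold lower number from compound 2 to compound 3 (0.30 log units; that floor lies within the scatter). For compound 3 the estimate is 5000 nM, with an estimated range of 1500 nM to 20000 nM.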

Compound 3, half-maximal effective concentration: > 10000 nM
Compound 3 ended at the assay's limit; the forecaster's own chance of this, stated with the estimate: 65%; at least 2.0-fold (0.30 log units) between middle value and limit.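

Among the compounds shown here, no step among compound 1, compound 2 and compound 3 can be read in this assay: all three values are limits, not numbers. Going by these compounds, whether isopropoxycarbonyl, 1,3-benzothiazol-2-yl and 1-benzofuran-2-yl differ at all on the shared core stays open.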